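Dropping a Bromine: Expected Cytotoxicity of Compound 3

The compounds below may be only part of what the source reports. "The series", "measured", "known", "first", "only" and "open" are said of these compounds alone.

Compound 1, `Cc1ccc(C2=NN(c3nc(-c4ccccc4)cs3)C(c3ccc(F)cc3)C2)s1`, in an ADME assay on NIH3T3 cells (Mus musculus) for cytotoxicity, read by XTT assay, with a stated time of 24 h (on this read-out higher numbers stand for weaker inhibition and lower numbers for stronger inhibition), gives > 500 ug/mL, which is a limit of the assay and not a number.
Compound 2, `Fc1ccc(C2CC(c3ccc(Cl)s3)=NN2c2nc(-c3ccc(Br)cc3)cs2)cc1`, in this assay gives > 500 ug/mL, again a limit and not a number.

Compound 2 therefore stands at the limit of > 500 ug/mL in this assay, at which 2 of the 2 values shown sit; no measured number separates it from compound 1. Compound 3, `Fc1ccc(C2CC(c3ccc(Cl)s3)=NN2c2nc(-c3ccccc3)cs2)cc1`, differs from compound 2 by hydrogen in place of bromo on an aromatic carbon. Among the compounds with values here, no measured step of this kind exists here, so the step that the limit leaves unreadable from compound 2 to compound 3 is expected to be none beyond the scatter. Compound 3 is expected to give about 600 ug/mL, in the range 250 ug/mL to 1500 ug/mL, most likely again reported only as a limit.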

Compound 3, half-maximal inhibitory concentration: > 500 ug/mL
Compound 3: no number, only a limit; the forecaster's own chance of this, stated with the estimate: 85%; the middle value is on the limit's open side.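

No step can be read between compound 1, compound 2 and compound 3, because each gives only a limit and not a number: the limit of > 500 ug/mL in this assay, at which 3 of the 3 values shown sit.

On these data alone, what stays open is how much cytotoxicity, if any, each compound has in this assay, and whether hydrogen in place of bromo changes it.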